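This account rests on a few compounds, and the source may have more. Where it says the series, first, only, none or still open, it means among the compounds named here.

Measured in a physicochemical assay for solubility, read by spectrophotometry, using the shake flask method, with a stated time of 2 days, at pH 6.5; a lower number here means a less soluble compound, a higher number a more soluble compound:
- compound 1 `O=C(O)COc1ccc2nc(-c3cn(-c4ccc(O)c(F)c4)nn3)ccc2c1`: 37 ug/mL
- compound 2 `O=C(O)COc1ccc2nc(-c3cn(-c4ccccc4)nn3)ccc2c1`: 1050 ug/mL
- compound 3 `COCCOc1cccc(Oc2cccc3nc(-c4cn(-c5ccc(O)c(F)c5)nn4)ccc23)c1`: 6.1 ug/mL

At 37 ug/mL, compound 1 stands second highest of the three numbers, with compound 3 lower and compound 2 higher, both gaps beyond the scatter. The next compound, compound 4 `NCCOCCOc1ccc2nc(-c3cn(-c4ccc(O)c(F)c4)nn3)ccc2c1`, has not yet been measured. It differs from compound 1 as follows: (2-aminoethoxy)methyl in place of carboxy on a saturated chain carbon bound to an oxygen on an aromatic ring. In words, (2-aminoethoxy)methyl stands in place of carboxy on a saturated chain carbon bound to an oxygen on an aromatic ring.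

Among the measured compounds shown here, only one measured step is available, a 28-fold higher number from compound 1 to compound 2 (1.45 log units; beyond the scatter), and it lies at a different place, on an aromatic nitrogen. It shows that this assay can move widely in this series, but it gives no direction for the present change. For the measured compounds named here, no measured pair isolates this change, so no step beyond the scatter is expected, though the uncertainty is wide. The estimated step is a 1.4-fold higher number from compound 1 to compound 4 (0.13 log units; within the scatter). For compound 4 the estimated value is 50 ug/mL, with an expected range from 10 ug/mL to 250 ug/mL.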

Compound 4, solubility: 9.1 ug/mL
Beside the measured number, compound 4's estimate is 5.5-fold (0.74 log units) above it; measured number outside the range, below it.
By their numbers in this assay, from the lowest: compounds 3 and 4 (each within the scatter of the next); then compound 1; then compound 2.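

In this assay, (2-aminoethoxy)methyl in place of carboxy gives a 4.1-fold lower number from compound 1 to compound 4 (0.61 log units; beyond the scatter) at this place, a saturated chain carbon bound to an oxygen on an aromatic ring. Among the compounds shown here, this is the first measured step at this place, and it shows that the solubility reading responds here as well as on the aromatic nitrogen, where a 28-fold higher number from compound 1 to compound 2 (1.45 log units; beyond the scatter) is the larger step. Nothing measured on these compounds accounts for the lower number.

The compounds shown change the chain and its end group together, so a shorter chain ending in an amine or a longer chain ending in a carboxylic acid would be needed to tell the two apart. On these data alone, whether the same change gives a similar step with phenyl on the aromatic nitrogen also remains open.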